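Diaryl pyrazoline thiocarboxamides: antiproliferative series, next analogue

The source may hold more compounds than are shown below. What is called first, only, known or untested is meant among the compounds shown, and "the series" means these compounds.

Measured so far:
compound 1 `Fc1ccc(C2=NN(C(=S)Nc3ccccc3)C(c3ccc4c(c3)OCCO4)C2)cc1` — 15700 nM
compound 2 `S=C(Nc1ccccc1)N1N=C(c2ccc(Cl)c(Cl)c2)CC1c1ccc2c(c1)OCCO2` — 41900 nM

In a functional assay on A-375 cells (Homo sapiens) for antiproliferative activity, read by MTT assay, with a stated time of 48 h (a lower number here means a stronger inhibitor of growth, a higher number a weaker inhibitor of growth), compound 1 gives 15700 nM. In this assay compound 2 gives 41900 nM. Going by the values given here, compound 2 thus stands at the higher of the two numbers recorded so far, its nearest neighbour being compound 1, the gap being the only step: a 2.7-fold higher number from compound 1 to compound 2 (0.43 log units; beyond the scatter).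

The next analogue is compound 3 `Cc1ccc(C2=NN(C(=S)Nc3ccccc3)C(c3ccc4c(c3)OCCO4)C2)cc1C`. It differs from compound 2 in one place: 3,4-dimethylphenyl in place of 3,4-dichlorophenyl on a carbon with a double bond to nitrogen. Among the compounds with values here, the only measured step that bears on this position is the exchange of the aryl group on the same carbon from compound 1 to compound 2, which moved this assay modestly and upward. Within the data shown here, that step says the position tolerates a change of this size, but it gives no direction for replacing two chlorines by two methyls, and no other pair speaks to it. A step of modest size in either direction, or none beyond the scatter, is therefore expected: a 1.4-fold lower number from compound 2 to compound 3 (0.15 log units; within the scatter).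

For compound 3 the estimate in this assay is 30000 nM, within a range from 10000 nM to 90000 nM.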

Compound 3, concentration for 50% growth inhibition: 61300 nM
For compound 3 the middle estimate is 2.0-fold (0.31 log units) below the measured one; low and high end bracket the measured number.
By their numbers in this assay, from the lowest: compound 1; then compounds 2 and 3 (each within the scatter of the next).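

In this assay, 3,4-dimethylphenyl in place of 3,4-dichlorophenyl gives a 1.5-fold higher number from compound 2 to compound 3 (0.17 log units; within the scatter), so at this position, on a carbon with a double bond to nitrogen, the two groups cannot be told apart in this read-out, although methyl and chlorine differ in their atoms. The same position separates 3,4-dimethylphenyl from 4-fluorophenyl, with a 3.9-fold higher number from compound 1 to compound 3 (0.59 log units; beyond the scatter); together with the earlier dichloro step, this places both 3,4-disubstituted phenyl groups on the weaker side of compound 1, and none of the three compounds goes against that pattern, which rests on these compounds alone. The compounds shown offer no measurement that accounts for these differences.

Still open, on these data alone, is whether compound 1 owes its lower number to the fluorine itself or to having a single substituent on the phenyl ring, a question that plain phenyl, 4-chlorophenyl and 4-methylphenyl at this position would address. Also open, as far as these compounds go, is how the series responds to an amine or a carboxylic acid on this phenyl ring, or to any replacement of the 2,3-dihydro-1,4-benzodioxin-6-yl group, which is common to all three compounds.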